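A few compounds are considered here, and "the series" means these few. Any claim that something is new, unique, unknown or untested is made for them only; others in the source may bear on it.

Measured compounds in the series:
compound 1, `CC(C)(C)OC(=O)CCCN1CCc2c(sc(NC(=O)Nc3ccc(Cl)cc3)c2C(N)=O)C1`: 560 nM
compound 2, `CCN1CCc2c(sc(NC(=O)[C@@H]3CCCN3)c2C(N)=O)C1`: > 25000 nM
compound 3, `CCN1CCc2c(sc(NC(=O)Nc3ccc4ccccc4c3)c2C(N)=O)C1`: 1780 nM

In a functional assay (strain AB) with Danio rerio as the target, read by microscopy, with a stated time of 1 h (a lower number here means that less compound is needed, a higher number that more compound is needed for the effect), compound 1 gives 560 nM, the lowest of the two numbers obtained so far. Compound 3 gives 1780 nM in this assay, a gap beyond the usual scatter. For compound 2 the assay returns only a limit and no number; compound 2 sits at the limit of > 25000 nM in this assay, at which 1 of the 3 values shown sits.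

Compound 4, `CC(C)(C)CN1CCc2c(sc(NC(=O)Nc3ccc(Cl)cc3)c2C(N)=O)C1`, has not yet been measured in this assay. It differs from compound 1 in one place: tert-butyl in place of 2-(tert-butoxycarbonyl)ethyl on a saturated chain carbon bound to an amine nitrogen in a ring. The shared core of compound 1 and compound 4 is unchanged, as is the urea side of the molecule.

Among the measured compounds shown here, no pair of measured compounds differs in the same way, so there is no measured step to lean on. The change removes the ester end of the chain and shortens what hangs on the ring nitrogen. On the numbers shown nothing argues for a large move in either direction; the step from compound 1 to compound 4 is expected to be modest, most likely a small rise in the number, and it may well fall within the scatter. The estimate for compound 4 in this assay is 900 nM, with a range from 250 nM to 3500 nM, which means an expected step of a 1.6-fold higher number from compound 1 to compound 4 (0.21 log units; within the scatter).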

Compound 4, half-maximal effective concentration: 5560 nM
Compound 4: the middle estimate sits 6.2-fold (0.79 log units) below what was measured, outside the stated range (above it).
By their numbers in this assay, from the lowest: compound 1; then compound 3; then compound 4. At a limit, above all of these: compound 2.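

In this assay, among the compounds shown here, tert-butyl in place of 2-(tert-butoxycarbonyl)ethyl on a saturated chain carbon bound to an amine nitrogen in a ring gives a 9.9-fold higher number from compound 1 to compound 4 (1.00 log units; beyond the scatter) with the shared core and the urea side unchanged, and this is the first step that can be read in one place. This place therefore matters for the number, at least for this pair, since the step lies beyond the scatter. The change does two things at once, trading 9 heavy atoms that include 2 oxygen for 4 carbon, so this one step cannot separate loss of the ester from loss of chain length.

The measurements shown offer nothing that accounts for the step. As far as these compounds go, a longer all-carbon chain in this place would test chain length apart from the ester, while a carboxylic acid or an amine at the chain end would test whether the lower number depends on the tert-butyl ester itself; both questions remain open here.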